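Swapping dimethylamino for pyrrolidine on a sulfonamide core

The compounds below may be only part of what the source reports. "The series", "measured", "known", "first", "only" and "open" are said of these compounds alone.

Measured so far:
compound 1 `CN(C)c1ccccc1S(=O)(=O)Nc1ccc(-c2cccc(Cl)c2)nn1`: 118 nM
compound 2 `Cc1ccc(S(=O)(=O)Nc2ccc(-c3cccc(N(C)C)c3)nn2)cc1`: 82.5 nM
compound 3 `Cc1ccc(S(=O)(=O)Nc2ccc(-c3ccccc3N(C)C)nn2)cc1`: 4.5 nM

All three were tested in an assay on mitochondria from liver for inhibition of kynurenine 3-monooxygenase (Mus musculus), read by LC-MS, with stated times of 5 min and 30 min; on this read-out higher numbers stand for weaker inhibition and lower numbers for stronger inhibition. On that read-out compound 1 gives 118 nM, compound 2 gives 82.5 nM, and compound 3 gives 4.5 nM. Compound 3 stands lowest of the three numbers, and its distance to each of the other two is wider than repeated measurements of this kind usually scatter, so among the measured compounds it is the most potent one.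

Compound 4 `Cc1ccc(S(=O)(=O)Nc2ccc(-c3ccccc3N3CCCC3)nn2)cc1` has not yet been measured. It differs from compound 3 in a single place: pyrrolidin-1-yl in place of dimethylamino on an aromatic carbon, in words pyrrolidin-1-yl in place of dimethylamino on an aromatic carbon. Within the data shown here, no measured pair in this set carries that swap, so there is no step to lean on. The nitrogen stays where it was and the added atoms close a small ring, which is a modest alteration in size; the expected step is therefore small, perhaps none beyond the usual scatter, in no firm direction. Compound 4 is estimated at 6 nM, with a range from 1.5 nM to 25 nM. The expected step of a 1.3-fold higher number from compound 3 to compound 4 (0.12 log units; within the scatter) is accordingly slight.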

Compound 4, half-maximal inhibitory concentration: 1.7 nM
For compound 4 the middle estimate is 3.5-fold (0.55 log units) above the measured one; low and high end bracket the measured number.
By their numbers in this assay, from the lowest: compound 4; then compound 3; then compounds 2 and 1 (each within the scatter of the next).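

In this assay, tying the two methyl groups of dimethylamino into the pyrrolidin-1-yl ring, on an aromatic carbon ortho to a large group, gives a 2.6-fold lower number from compound 3 to compound 4 (0.42 log units; beyond the scatter), a modest step. The step lies beyond the usual scatter of repeated measurements. Among these compounds, this is the first comparison in the set where only this group changes, and it shows that the position accepts a larger, ring-closed amine while inhibition grows stronger rather than being lost. Nothing available here says why the ring outperforms the open dimethylamino group.

Still open, from the compounds shown here alone, is whether the gain depends on the size and makeup of the ring, which a piperidine or a morpholine at the same position would test, or on the ring nitrogen itself, which an isopropyl or cyclopentyl group with carbon in its place would test. Going by these compounds, it is also open whether the same swap would carry over to compound 1, whose dimethylamino group sits elsewhere in the molecule and which differs from compound 4 in more than one place.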